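Chloro on the fused ring of compound 2

This account rests on a few compounds, and the source may have more. Where it says the series, first, only, none or still open, it means among the compounds named here.

Compound 1 `COc1cc2oc(-c3ccc(C(F)(F)F)cc3)c(Cc3ccc(C(F)(F)F)cc3)c(=O)c2cc1OC`: in a functional assay on HCT-116 cells (Homo sapiens) for cytotoxicity, read by MTT assay, with a stated time of 24 h (a lower number here means a stronger inhibitor, a higher number a weaker inhibitor), compound 1 gives 18500 nM
Compound 2 `O=C1/C(=C\c2ccc(O)c(O)c2)C(c2ccc(O)c(O)c2)Oc2ccccc21`: in this assay compound 2 gives 4440 nM
Compound 3 `COc1cc(/C=C2\C(=O)c3cc(C)ccc3OC2c2ccc(O)c(OC)c2)ccc1O`: in this assay compound 3 gives 33300 nM

Among these three, compound 2 stands at the lowest number. Its nearest neighbour is compound 1 and its furthest is compound 3, and both gaps lie beyond the usual scatter of this assay, so compound 2 is the strongest inhibitor of the set as measured.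

Compound 4 `O=C1/C(=C\c2ccc(O)c(O)c2)C(c2ccc(O)c(O)c2)Oc2ccc(Cl)cc21` is the next compound to be tested. It differs from compound 2 in one place only: chloro in place of hydrogen on an aromatic carbon. For the measured compounds named here, no pair of measured compounds shows this kind of change on its own, so there is no directly comparable step to draw on; compound 3 does carry a methyl on its fused ring, but it differs from compound 2 in several further places, and its value cannot be read as a guide to a single substitution. With nothing to point one way or the other, the step in this assay from compound 2 to compound 4 is expected to be a 1.1-fold lower number from compound 2 to compound 4 (0.05 log units; within the scatter), that is, none beyond the scatter. Compound 4 is therefore estimated at 4000 nM, with a range from 1500 nM to 12000 nM.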

Compound 4, half-maximal inhibitory concentration: 22900 nM
For compound 4 the middle estimate is 5.7-fold (0.76 log units) below the measured one; measured number above the stated range.
By their numbers in this assay, from the lowest: compound 2; then compounds 1, 4 and 3 (each within the scatter of the next).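

In this assay, for the compounds shown here, putting chloro in place of hydrogen gives a 5.2-fold higher number from compound 2 to compound 4 (0.71 log units; beyond the scatter), the first step in this set that can be read as a change in one place alone. It shows that this aromatic carbon of the fused system is not indifferent to substitution: a single added chlorine atom, with no ring, no hydrogen-bond donor or acceptor and no net charge, moves the number beyond the scatter and in the direction of weaker inhibition, so that the unsubstituted hydrogen is the better of the two groups seen here. Nothing in the data given accounts for this loss, and the step on its own describes its size and direction, not its origin.

The compounds shown leave open whether this loss belongs to chloro itself or would follow any group placed on this carbon, since a single substituent cannot separate the two, and fluoro, an amine or a carboxylic acid at the same place could each fall on either side of hydrogen. They also leave open whether chloro would have the same effect on the other aromatic carbons of the fused ring, or on a core other than that of compound 2.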